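A few compounds are considered here, and "the series" means these few. Any claim that something is new, unique, unknown or untested is made for them only; others in the source may bear on it.

Measured compounds:
Compound 1 `COc1ccc(/C=C2\C(=O)N(Cc3cn([C@@H]4O[C@H](COC(C)=O)[C@@H](OC(C)=O)[C@H](OC(C)=O)[C@H]4OC(C)=O)nn3)c3ccccc32)cc1OC`: 23500 nM
Compound 2 `CC(=O)OC[C@H]1O[C@@H](n2cc(CN3C(=O)/C(=C/c4cccs4)c4ccccc43)nn2)[C@H](OC(C)=O)[C@@H](OC(C)=O)[C@@H]1OC(C)=O`: 28100 nM

In a functional assay on MCF7 cells (Homo sapiens) for cytotoxicity, read by sulforhodamine B assay, with a stated time of 48 h (on this read-out higher numbers stand for weaker inhibition and lower numbers for stronger inhibition), compound 1 gives 23500 nM, and in the same assay compound 2 gives 28100 nM. Compound 2 stands highest of the two numbers shown, yet its only neighbour is compound 1, and the distance between them is within the usual scatter of the assay, so the two values show nothing that separates the thienyl-bearing compound from the dimethoxyphenyl-bearing one.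

Compound 3 `CC(=O)OC[C@H]1O[C@@H](n2cc(CN3C(=O)/C(=C\c4cccs4)c4ccccc43)nn2)[C@H](OC(C)=O)[C@@H](OC(C)=O)[C@@H]1OC(C)=O` is the next compound, and it carries no new group: the two compounds have the same atoms and bonds and differ only in configuration as drawn: 1 of 6 stereo elements differ; a double bond is drawn E in compound 2 and Z in compound 3. Within the data shown here, no pair of measured compounds differs in this way, so there is no measured step to lean on. On a change that keeps every atom and bond and alters only the geometry of one double bond, the expected step in this assay from compound 2 to compound 3 is a 1.2-fold lower number from compound 2 to compound 3 (0.07 log units; within the scatter), with no clear direction beyond the scatter. Compound 3 is therefore expected to give about 24000 nM, within a range from 8000 nM to 70000 nM.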

Compound 3, half-maximal inhibitory concentration: 36100 nM
For compound 3 the middle estimate is 1.5-fold (0.18 log units) below the measured one; low and high end bracket the measured number.
By their numbers in this assay, from the lowest: compounds 1, 2 and 3 (each within the scatter of the next).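

In this assay, the pair that isolates the geometry of the double bond gives a 1.3-fold higher number from compound 2 to compound 3 (0.11 log units; within the scatter), so at this position the drawn E and Z forms of the thiophen-2-yl compounds are not separated by the assay. The other step, for thiophen-2-yl in place of 3,4-dimethoxyphenyl on the double-bonded chain carbon, gives a 1.5-fold higher number from compound 1 to compound 3 (0.19 log units; within the scatter), so compound 3 also stays within the scatter of compound 1, and neither change has yet moved the read-out beyond it. The first of these steps can be read as a test of double-bond geometry alone, with no other structural change involved: the fact that compounds 2 and 3 differ only in the configuration as drawn.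

The compounds shown leave open whether the same switch in geometry would also stay within the scatter with 3,4-dimethoxyphenyl on the chain carbon, as the only pair that tests it carries thiophen-2-yl. They also leave open how the read-out would respond to an aromatic group carrying an amine or a carboxylic acid at that carbon, or to free hydroxyl groups in place of the acetate esters on the sugar.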